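The source may hold more compounds than are shown below. What is called first, only, known or untested is meant among the compounds shown, and "the series" means these compounds.

Measured so far in an assay on Sf9 cells for inhibition of protein deacetylase HDAC6 (Homo sapiens), read by fluorescence, with stated times of 90 min and 30 min; on this read-out higher numbers stand for weaker inhibition and lower numbers for stronger inhibition:
compound 1 `Cc1ccc(NC(=O)CCN(Cc2ccc(C(=O)NO)cc2)C(=O)c2cc(C)cc(C)c2)cc1` gives 31.1 nM
compound 2 `Cc1cc(C)cc(C(=O)N(CCC(=O)NCc2ccccc2)Cc2ccc(C(=O)NO)cc2)c1` gives 20.5 nM
compound 3 `Cc1ccc(CNC(=O)CCN(Cc2ccc(C(=O)NO)cc2)C(=O)c2ccc(N(C)C)cc2)cc1` gives 14.4 nM

Compound 3 shows the lowest number of the three; its gap to compound 2 lies within the scatter, its gap to compound 1 beyond it. Compound 4 `Cc1ccc(NC(=O)CCN(Cc2ccc(C(=O)NO)cc2)C(=O)c2ccc(N(C)C)cc2)cc1` is not yet measured. The change from compound 3 to compound 4 is 4-methylphenyl in place of 4-methylbenzyl on an amide-type nitrogen. Within the data shown here, the only measured step at this place is a 1.5-fold lower number from compound 1 to compound 2 (0.18 log units; within the scatter), which runs the other way and uses benzyl rather than 4-methylbenzyl; read in reverse it points to a small rise at most. The step from compound 3 to compound 4 is therefore expected to be a 1.4-fold higher number from compound 3 to compound 4 (0.14 log units; within the scatter), not beyond the scatter. Compound 4 is estimated at 20 nM, with a range of 10 nM to 40 nM.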

Compound 4, half-maximal inhibitory concentration: 19.5 nM
Estimate against measurement, compound 4: 1.0-fold (0.01 log units) above; low and high end bracket the measured number.
By their numbers in this assay, from the lowest: compounds 3, 4, 2 and 1 (each within the scatter of the next, the first and the last beyond it).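

In this assay, the change on the amide-type nitrogen gives a 1.4-fold higher number from compound 3 to compound 4 (0.13 log units; within the scatter), so with 4-(dimethylamino)phenyl on the carbonyl carbon, 4-methylbenzyl and 4-methylphenyl are not separated here. Among these compounds, the first reading of the carbonyl-carbon place, a 1.6-fold lower number from compound 1 to compound 4 (0.20 log units; within the scatter), likewise shows no separation between 4-(dimethylamino)phenyl and 3,5-dimethylphenyl. No data on hand offer a reason for either step.

Still open, going by these compounds, is whether a carboxylic acid or a primary amine in place of the methyl on 4-methylphenyl, or a longer chain on the amide-type nitrogen, would give a step beyond the scatter.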